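Swapping a Pyridine for an Imidazole on a Weak Binder

The source may hold more compounds than are shown below. What is called first, only, known or untested is meant among the compounds shown, and "the series" means these compounds.

Compound 1 `CCCCc1nc(/C=N/Nc2nc(N)c3ncn([C@@H]4O[C@H](CO)[C@@H](O)[C@H]4O)c3n2)c(Cl)[nH]1` is the strong binder here: in an assay on CHO-K1 cells for displacement of a labelled ligand from adenosine receptor A1 (Homo sapiens), read by scintillation counting, with a stated time of 60 min (on this read-out higher numbers stand for weaker inhibition and lower numbers for stronger inhibition), compound 1 gives 12 nM. Among the compounds with values here, compound 2 `Nc1nc(N/N=C/c2ccc(-c3ccccn3)cc2)nc2c1ncn2[C@@H]1O[C@H](CO)[C@@H](O)[C@H]1O` stands at the highest of the two numbers known, far weaker than compound 1; in this assay compound 2 gives 7540 nM. Compound 3 `Nc1nc(N/N=C/c2ccc(C(F)(F)F)cc2C(F)(F)F)nc2c1ncn2[C@@H]1O[C@H](CO)[C@@H](O)[C@H]1O` yields only a limit of the measurement, > 10000 nM, not a number (the limit of > 10000 nM in this assay, at which 1 of the 3 values shown sits).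

Compound 4 `Nc1nc(N/N=C/c2ccc(-n3ccnc3)cc2)nc2c1ncn2[C@@H]1O[C@H](CO)[C@@H](O)[C@H]1O` is still unmeasured. It differs from compound 2 in one place: 1H-imidazol-1-yl in place of pyridin-2-yl on an aromatic carbon. Within the data shown here, no measured pair shows what such a swap does, so the step of a 1.1-fold higher number from compound 2 to compound 4 (0.03 log units; within the scatter) is expected to be small, no larger than the scatter, in either direction. Compound 4 is estimated at 8000 nM, likely between 2000 nM and 30000 nM.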

Compound 4, inhibition constant: > 10000 nM
Compound 4 gave a limit, no number; the forecaster's own chance of this, stated with the estimate: 35%; middle value at least 1.2-fold (0.09 log units) away from the limit.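

As far as these compounds go, on this aromatic carbon, 1H-imidazol-1-yl in place of pyridin-2-yl gives an at least 1.3-fold higher number from compound 2 to compound 4 (0.12 log units; that floor lies within the scatter), so the swap recovers no binding, although the true size of the step stays unknown. An imidazole ring alone does not bring back the strength of compound 1, as 4-(1H-imidazol-1-yl)phenyl in place of 2-butyl-5-chloro-1H-imidazol-4-yl gives an at least 830-fold higher number from compound 1 to compound 4 (2.92 log units; beyond the scatter). The result for compound 4 is a limit, not a number: the limit of > 10000 nM in this assay, at which 2 of the 4 values shown sit.

From the compounds shown here alone, how far compound 4 lies past that limit remains open. So does whether an amine, a carboxylic acid or a longer chain on this carbon would bind any better than these two rings.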